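A few compounds are considered here, and "the series" means these few. Any claim that something is new, unique, unknown or untested is made for them only; others in the source may bear on it.

Compound 1, `CCC(C(=O)N1CCN(c2ccc(C(F)(F)F)cc2)CC1)N1C(=O)CCC1=O`, was tested in a functional assay on the whole organism (strain Swiss) with Mus musculus as the target, in the maximal electroshock model, with a stated time of 0.5 h, at a dose of 300 mg/kg by the intraperitoneal route (a lower number here means a weaker effect, a higher number a stronger effect of the compound at the dose given), where compound 1 gives 0%. Compound 3, `CC(C(=O)N1CCN(c2ccccc2Cl)CC1)N1C(=O)CCC1=O`, gives 0%, level with compound 1 at the digits shown, and together they hold the lowest of the three numbers. Compound 2, `CC(C(=O)N1CCN(c2ccc(C(F)(F)F)cc2)CC1)N1C(=O)CCC1=O`, gives 25%. The step from compound 1 to compound 2 is a number 25 percentage points higher from compound 1 to compound 2 (beyond the scatter), the only measured step between two of these compounds that differ in one place, and it comes from hydrogen in place of methyl on a saturated chain carbon.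

Compound 4, `CCC(C(=O)N1CCN(c2ccc(F)cc2)CC1)N1C(=O)CCC1=O`, has not yet been measured in this assay. Its difference from compound 1 is fluoro in place of trifluoromethyl on an aromatic carbon. Within the data shown here, no measured step alters the aromatic ring in this way. Among the measured compounds shown here, compound 2 gives 25% while compound 3 gives 0%, but those two are not separated by a single change, so they show only that different aromatic groups can go with either number. The step from compound 1 to compound 2 is no guide to fluoro in place of trifluoromethyl, and with compound 1 already at the lowest number there is no reason to expect a large rise. Compound 4 is therefore expected to give 5%, between 0% and 25%, which means an expected step of a number 5 percentage points higher from compound 1 to compound 4 (within the scatter).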

Compound 4, a percentage reported as activity, at one dose (the size of the read-out at that dose, not a potency): 25%
Beside the measured number, compound 4's estimate is 20 percentage points below it; measured number inside the range.
By their numbers in this assay, from the lowest: compounds 1 and 3 (each within the scatter of the next); then compounds 2 and 4 (each within the scatter of the next).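

On the core of compound 1, the aromatic carbon para to a large group turns out to be a place where a single change can alter the read-out: in this assay, fluoro in place of trifluoromethyl gives a number 25 percentage points higher from compound 1 to compound 4 (beyond the scatter) and lies beyond the usual scatter. Among these compounds, until now, the only single change with a measured effect was on the saturated chain, so the earlier compounds could not show that a change on the aromatic ring alone, with the chain left as it is in compound 1, goes with a higher number. This is still a read-out at one dose and not a potency, and no measurement shown gives a reason for the step.

The compounds shown leave open how hydrogen, chloro, methoxy or nitrile on this same aromatic carbon would compare with fluoro and trifluoromethyl. They also leave open whether fluoro on the ring would add to the chain change seen in a number 25 percentage points higher from compound 1 to compound 2 (beyond the scatter) if both changes stood in one compound, or whether a longer chain would lower the number again.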